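Ethyl extension on the side chain, carbamate and glycinamide series

The source may hold more compounds than are shown below. What is called first, only, known or untested is meant among the compounds shown, and "the series" means these compounds.

Compound 1 `CCOC(=O)Nc1cccc2c1CN(C)CC2c1ccccc1` gives 2.5 mg/kg in a functional assay on the whole organism for inhibition of sodium-dependent dopamine transporter (Mus musculus); on this read-out higher numbers stand for an effect only at larger amounts of compound and lower numbers for an effect already at smaller amounts. Within the data shown here, compound 2 `CCCCOC(=O)Nc1cccc2c1CN(C)CC2c1ccccc1`, which carries ethyl in place of hydrogen on a saturated chain carbon, two bonds along the chain from an oxygen next to a carbonyl group, gives 12 mg/kg in this assay; the step of a 4.8-fold higher number from compound 1 to compound 2 (0.68 log units; beyond the scatter) is the one counted change measured so far.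

Compound 3 `CCNCC(=O)Nc1cccc2c1CN(C)CC2c1ccc(C)cc1` gives about 15 mg/kg in this assay; the values of compound 3 and compound 2 lie within the scatter of each other, while compound 3 stands beyond the scatter from compound 1. The difference between the core of compound 3 and the core of compound 1 is not broken down here.

Compound 4 `CCCCNCC(=O)Nc1cccc2c1CN(C)CC2c1ccc(C)cc1` has not been measured. It carries ethyl in place of hydrogen on a saturated chain carbon, two bonds along the chain from an amine nitrogen. This is the same kind of change as that from compound 1 to compound 2, but not the same: there the place is on a saturated chain carbon, two bonds along the chain from an oxygen next to a carbonyl group, here it is on a saturated chain carbon, two bonds along the chain from an amine nitrogen. Among the measured compounds shown here, with only one measured precedent, and that at a different place, the expectation rests on the step of a 4.8-fold higher number from compound 1 to compound 2 (0.68 log units; beyond the scatter) alone, and is held loosely.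

Compound 4 is expected to give 40 mg/kg in this assay, between 15 mg/kg and 110 mg/kg. For the measured compounds named here, the expected step of a 2.7-fold higher number from compound 3 to compound 4 (0.43 log units; beyond the scatter) is estimated to run in the same direction as the one measured step of this kind, though a smaller or absent step would not surprise. That direction rests on a 4.8-fold higher number from compound 1 to compound 2 (0.68 log units; beyond the scatter), the only shown step for this kind of change.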

Compound 4, dose for half-maximal effect: 14 mg/kg
Compound 4: the middle estimate sits 2.9-fold (0.46 log units) above what was measured, outside the stated range (below it).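

In this assay, ethyl in place of hydrogen on a saturated chain carbon, two bonds along the chain from an amine nitrogen, gives a 1.1-fold lower number from compound 3 to compound 4 (0.03 log units; within the scatter), so going from ethylamino to butylamino leaves the read-out within the scatter on this core. The earlier extension on the carbamate chain therefore does not carry over as a fixed step, and its size cannot be transferred from one core to the other: the same change on two cores in this assay, a 4.8-fold higher number (0.68 log units; beyond the scatter) from compound 1 to compound 2 and a 1.1-fold lower number (0.03 log units; within the scatter) from compound 3 to compound 4, 5.1-fold (0.71 log units) apart, beyond the scatter of two such steps. This does not show what separates the two outcomes, since the two pairs differ from each other both in the place of the change, an oxygen next to a carbonyl group in one and an amine nitrogen in the other, and in the rest of the core, and each outcome rests on a single pair.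

The compounds shown leave open whether the flat step on the amine side persists with a longer chain such as hexyl or with a benzyl group on the amine nitrogen. Also open, going by these compounds, is how the ethyl and butyl carbamates would read on the core of compound 3, a pair that would separate the effect of the chain's surroundings from that of the core.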